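A few compounds are considered here, and "the series" means these few. Any claim that something is new, unique, unknown or untested is made for them only; others in the source may bear on it.

Compound 1 `COc1ccc(Cn2cc(CSC(=S)N3CCN(C(=O)NC(C)C)CC3)nn2)cc1` and compound 2 `CCN(C)C(=O)N1CCN(C(=S)SCc2cn(Cc3ccc(OC)cc3)nn2)CC1` share one core and differ only at a carbonyl carbon, where compound 2 carries ethyl(methyl)amino in place of isopropylamino (ethyl(methyl)amino in place of isopropylamino on a carbonyl carbon). Both were tested in a functional assay on MGC-803 cells (Homo sapiens) for cytotoxicity, read by MTT assay, with a stated time of 72 h; a higher number here means a weaker inhibitor, a lower number a stronger inhibitor. Compound 1 gives 99200 nM in this assay. Compound 2 gives 87900 nM in this assay. The step from compound 1 to compound 2 is a 1.1-fold lower number from compound 1 to compound 2 (0.05 log units; within the scatter), so the two values cannot be told apart.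

Compound 3 `COc1cc(Cn2cc(CSC(=S)N3CCN(C(=O)NC(C)C)CC3)nn2)cc(OC)c1OC` has a different core; how its core differs from that of compound 1 is not broken down here. For compound 3 this assay gives only a limit, > 128000 nM, and not a number. That this limit exists is shown by the limit of > 128000 nM in this assay, at which 1 of the 3 values shown sits.

Compound 4 `CCN(C)C(=O)N1CCN(C(=S)SCc2cn(Cc3cc(OC)c(OC)c(OC)c3)nn2)CC1` is built from compound 3 by the same change that leads from compound 1 to compound 2: ethyl(methyl)amino enters in place of isopropylamino at a carbonyl carbon (ethyl(methyl)amino in place of isopropylamino on a carbonyl carbon). Among the measured compounds shown here, the one measured instance of this change, from compound 1 to compound 2, stayed within the usual scatter, so the step from compound 3 to compound 4 in this assay is expected to be equally small, a step that the limit leaves unreadable from compound 3 to compound 4. Since compound 3 reached only a limit, compound 4 is expected also to sit near or beyond that limit, with an estimated value of 140000 nM, most likely between 70000 nM and 300000 nM.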

Compound 4, half-maximal inhibitory concentration: 85700 nM
For compound 4 the middle estimate is 1.6-fold (0.21 log units) above the measured one, and the stated range covers the measured number.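

In this assay, putting ethyl(methyl)amino in place of isopropylamino on a carbonyl carbon gives an at least 1.4-fold lower number from compound 3 to compound 4 (0.17 log units; that floor lies within the scatter), and this figure is only a floor, not a full measure of the step. For compound 3 the assay gives a limit, > 128000 nM, and not a number, so the true step may be larger than this floor. The result therefore does not contradict the idea that the change carries from one core to the other as a small step, but it does not show that the change behaves the same way on both cores, as the side-by-side reading makes plain: the same change on two cores in this assay, a 1.1-fold lower number (0.05 log units; within the scatter) from compound 1 to compound 2 and an at least 1.4-fold lower number (0.17 log units; that floor lies within the scatter) from compound 3 to compound 4; the limit leaves it open whether they differ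

Only two cores and two amino groups are shown, so it remains open whether a ring amine such as pyrrolidine, or a longer chain such as dibutylamino, on the same carbonyl carbon would move the number in this assay beyond the scatter. Going by these compounds, it is also open how this change would read on a core carrying a carboxylic acid in place of the methoxy groups, and on a core where both partners of the pair give full numbers rather than a limit.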